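Replacing 2-cyanoethyl with 1,2-dihydroxyethyl: permeability notes

This account rests on a few compounds, and the source may have more. Where it says the series, first, only, none or still open, it means among the compounds named here.

- compound 1 `CCC1=C(c2cc(OC)c(OC)c(OC)c2)c2ccc(OC)c(O)c2CCC1`: 3.3 10^-6 cm/s
- compound 2 `COc1ccc2c(c1O)CCCC(CCCC#N)=C2c1cc(OC)c(OC)c(OC)c1`: 16.6 10^-6 cm/s

In an ADME assay on MDCKII-LE cells (Canis lupus familiaris) for permeability, in the apical to basolateral direction (on this read-out lower numbers stand for lower permeability and higher numbers for higher permeability), compound 2 stands at 16.6 10^-6 cm/s, the higher of the two numbers. Compound 3 `COc1ccc2c(c1O)CCCC(CC(O)CO)=C2c1cc(OC)c(OC)c(OC)c1` differs from it by 1,2-dihydroxyethyl in place of 2-cyanoethyl on a saturated chain carbon bound to a double-bonded ring carbon, with 1,2-dihydroxyethyl in place of 2-cyanoethyl on a saturated chain carbon bound to a double-bonded ring carbon. Among the measured compounds shown here, one measured step bears on this chain: a 5.0-fold higher number from compound 1 to compound 2 (0.70 log units; beyond the scatter). It was modest, and neither measured compound carries the entering group, so the guide is weak. A step of similar size towards a lower number is expected, a 4.2-fold lower number from compound 2 to compound 3 (0.62 log units; beyond the scatter). For compound 3 the estimate is 4 10^-6 cm/s, with an expected range of 1.3 10^-6 cm/s to 11 10^-6 cm/s.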

Compound 3, apparent permeability: 16.1 10^-6 cm/s
Beside the measured number, compound 3's estimate is 4.0-fold (0.60 log units) below it; the whole stated range lies below it.
By their numbers in this assay, from the lowest: compound 1; then compounds 3 and 2 (each within the scatter of the next).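

In this assay, 1,2-dihydroxyethyl in place of 2-cyanoethyl on a saturated chain carbon bound to a double-bonded ring carbon gives a 1.0-fold lower number from compound 2 to compound 3 (0.01 log units; within the scatter), so the hydrogen-bond donors absent from 2-cyanoethyl separate compound 2 and compound 3 by nothing beyond the scatter. Set against the shorter chain of compound 1, the same group gives a 4.9-fold higher number from compound 1 to compound 3 (0.69 log units; beyond the scatter), in the same direction as a 5.0-fold higher number from compound 1 to compound 2 (0.70 log units; beyond the scatter). No supporting data explain this result. Going by these compounds, whether an amine, a carboxylic acid or a longer chain at this place would stay level with compound 2 and compound 3 remains open.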